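Ester in place of amide on the carbonyl of compound 3

The source may hold more compounds than are shown below. What is called first, only, known or untested is meant among the compounds shown, and "the series" means these compounds.

Within the data shown here, compound 3 `CN(C)C(=O)c1ccc(NCc2cncn2Cc2ccc(-c3ccccc3)cc2)cc1-c1ccccc1` is one of three compounds measured so far on a shared core. In a toxicity assay on NIH3T3 cells (Mus musculus) for cytotoxicity, read by resazurin assay (a higher number here means that more compound is needed for the effect, a lower number that less compound is needed), compound 3 gives > 1000 nM, which is a limit of the assay and not a number. Compound 1 `c1ccc(-c2ccc(Cn3cncc3CNc3ccc(-c4ccc[nH]4)c(-c4ccccc4)c3)cc2)cc1` also reaches only a limit, giving > 10000 nM in this assay. Compound 2 `N#Cc1ccc(NCc2cncn2Cc2ccc(-c3ccccc3)cc2)cc1-c1ccccc1` gives > 1000 nM in this assay, again a limit. Because all three values are limits, the steps a step that the two limits leave unreadable from compound 1 to compound 2, a step that the two limits leave unreadable from compound 1 to compound 3 and a step that the two limits leave unreadable from compound 2 to compound 3 cannot be sized; the only footing is that two values sit at the limit of > 1000 nM in this assay, at which 2 of the 3 values shown sit, and one at the limit of > 10000 nM in this assay, at which 1 of the 3 values shown sits. Compound 4 `CCOC(=O)c1ccc(NCc2cncn2Cc2ccc(-c3ccccc3)cc2)cc1-c1ccccc1` differs from compound 3 by ethoxy in place of dimethylamino on a carbonyl carbon, so the carbonyl is kept and only its partner changes. The measured steps vary the same aromatic carbon, yet their sizes are unreadable, so they point in no direction. Compound 4 is therefore expected to stay at a limit, estimated at 5000 nM with a range from 1500 nM to 30000 nM. The expected step that the limit leaves unreadable from compound 3 to compound 4 is thus estimated as none beyond the scatter.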

Compound 4, half-maximal effective concentration: > 10000 nM
Compound 4 gave a limit, no number; the forecaster's own chance of this, stated with the estimate: 85%; middle value at least 2.0-fold (0.30 log units) from the limit.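

Compound 4 gives only a limit in this assay, and none of its steps to compound 1, compound 2 or compound 3 can be read. The compounds shown leave open whether any of these changes on the shared core alters the cytotoxicity, and by how much.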